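This account rests on a few compounds, and the source may have more. Where it says the series, first, only, none or still open, it means among the compounds named here.

Compound 1, with the structure `Cc1nc(Nc2ccccc2)sc1C(=O)/C=C/c1ccc(Cl)cc1`, was tested in a functional assay on Bel-7402 cells (Homo sapiens) for cytotoxicity, read by MTT assay; a higher number here means a weaker inhibitor, a lower number a stronger inhibitor. In this assay compound 1 gives > 25000 nM, which is a limit of the assay rather than a number. Compound 2, `Cc1nc(Nc2cccc(Cl)c2)sc1C(=O)/C=C/c1ccc(Cl)cc1`, differs from it by chloro in place of hydrogen on an aromatic carbon. In this assay compound 2 gives > 25000 nM, again a limit of the assay. The step that the two limits leave unreadable from compound 1 to compound 2 therefore has no readable size, because both values sit at the limit of > 25000 nM in this assay, at which 2 of the 3 values shown sit. Compound 3, `COc1cc(/C=C/C(=O)c2sc(Nc3cccc(Cl)c3)nc2C)cc(OC)c1OC`, carries a different core; how its core differs from that of compound 1 is not broken down here. In this assay compound 3 gives 14000 nM. Compound 4, `COc1cc(/C=C/C(=O)c2sc(Nc3ccc(Cl)c(Cl)c3)nc2C)cc(OC)c1OC`, has not yet been measured; it differs from compound 3 by chloro in place of hydrogen on an aromatic carbon. This is the same kind of change as that from compound 1 to compound 2, but the place differs: in compound 2 the chloro sits meta to a large group, while in compound 4 it sits ortho to a chloro group and para to a large group. Since the measured pair yields no readable size, the step from compound 3 to compound 4 is expected to be modest, a 1.4-fold lower number from compound 3 to compound 4 (0.15 log units; within the scatter). Compound 4 is thus estimated at 10000 nM, with a likely range from 4000 nM to 25000 nM.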

Compound 4, half-maximal inhibitory concentration: > 25000 nM
Compound 4: a limit, no number; the forecaster's own chance of this, stated with the estimate: 25%; middle value at least 2.5-fold (0.39 log units) from the limit.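

Carrying the chloro change onto the core of compound 3 gives an at least 1.7-fold higher number from compound 3 to compound 4 (0.25 log units; that floor lies within the scatter) in this assay, so the true step may be larger, but its floor alone does not show a real loss. The step from compound 1 to compound 2 cannot be read, and the chloro also enters at a different place in the two steps, so nothing here shows whether the change behaves alike on both cores. Only one value in the set is a true number, and the rest give no size to compare: the limit of > 25000 nM in this assay, at which 3 of the 4 values shown sit.

Still open, going by these compounds, is whether any other group on the 3-chlorophenyl ring, such as a fluoro, an amine or a carboxylic acid, would move the number of compound 3 in either direction. Also open, on these data alone, is how a plain phenyl, without any chloro, would read on the core of compound 3, a pairing that would show what the first chloro does there.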